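The compounds below may be only part of what the source reports. "The series", "measured", "known", "first", "only" and "open" are said of these compounds alone.

Compound 1 `Cc1ccc(C#Cc2cn(C/C=C\CN3C(=O)c4ccccc4C3=O)c(=O)[nH]c2=O)cc1` belongs to a small set of alkynyl-substituted uracil derivatives tested in an ADME assay on WI-38 cells (Homo sapiens) for cytotoxicity, read by MTT assay, with a stated time of 3 days; a higher number here means a weaker inhibitor, a lower number a stronger inhibitor. In this assay compound 1 gives only a limit, > 100000 nM, the compound reaching the limit of the test the limit of > 100000 nM in this assay, at which 1 of the 3 values shown sits, rather than a measured number. Two related compounds carry different groups on the alkyne: compound 2 `O=C1c2ccccc2C(=O)N1C/C=C/Cn1cc(C#CCCc2ccccc2)c(=O)[nH]c1=O`, which gives 31000 nM in this assay, and compound 3 `CCCCC#Cc1cn(C/C=C/CN2C(=O)c3ccccc3C2=O)c(=O)[nH]c1=O`, which gives 35000 nM. Within the data shown here, the only single-point step among them, a 1.1-fold higher number from compound 2 to compound 3 (0.05 log units; within the scatter), lies within the scatter of this assay. Compound 4 `CCCCc1ccc(C#Cc2cn(C/C=C\CN3C(=O)c4ccccc4C3=O)c(=O)[nH]c2=O)cc1` differs from compound 1 by propyl in place of hydrogen on a saturated chain carbon bound to an aromatic carbon, so the 4-methylphenyl of compound 1 becomes a 4-butylphenyl. Among the measured compounds shown here, no measured step concerns this kind of lengthening of a chain on the aromatic ring, and the one step that was measured, from compound 2 to compound 3, changed little, so no shift beyond the scatter is expected. Compound 4 is therefore expected to stay near the limit of compound 1, with an expected step of an at least 1.1-fold lower number from compound 1 to compound 4 (0.04 log units; that floor lies within the scatter). The estimate for compound 4 is 90000 nM, within a range from 25000 nM to 300000 nM.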

Compound 4, half-maximal inhibitory concentration: 17000 nM
Beside the measured number, compound 4's estimate is 5.3-fold (0.72 log units) above it, and the stated range ends above it.
By their numbers in this assay, from the lowest: compounds 4, 2 and 3 (each within the scatter of the next, the first and the last beyond it). At a limit, above all of these: compound 1.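

Propyl in place of hydrogen on a saturated chain carbon bound to an aromatic carbon gives an at least 5.8-fold lower number from compound 1 to compound 4 (0.76 log units; beyond the scatter), the first step in this assay that lies beyond the scatter. Among these compounds, this place therefore responds to a change in the chain, whereas the one earlier step, made on a different alkyne substituent, stayed within the scatter. The true size of the new step cannot be read, only its floor, since compound 1 stands at a limit: the limit of > 100000 nM in this assay, at which 1 of the 4 values shown sits.

The compounds shown leave open whether a longer chain such as hexyl would lower the number further, or whether the effect ends at butyl. They also leave open whether an amine or a carboxylic acid at the end of the chain would keep the lower number seen for compound 4.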